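Changing the sulfonyl group of compound 1

The source may report more compounds than this note shows. Statements on the series, on what has been measured and on what is new or still open speak of the compounds shown alone.

In a functional assay (Platelet, plasma) for inhibition, with Homo sapiens as the target (on this read-out lower numbers stand for stronger inhibition and higher numbers for weaker inhibition), compound 1 (`N#Cc1cc2c(nc1N1CCC(C(=O)NS(=O)(=O)Cc3cc(Cl)cc(Cl)c3)CC1)COC2=O`) gives 30500 nM and compound 2 (`Cc1ccc(CS(=O)(=O)NC(=O)C2(F)CCN(c3nc4c(cc3C#N)C(=O)OC4)CC2)cc1`) gives 32800 nM so the two lie within the usual scatter of each other. Compound 3 (`N#Cc1cc2c(nc1N1CC(C(=O)NS(=O)(=O)Cc3ccccc3)C1)COC2=O`) gives only a limit of > 300000 nM in this assay and no number.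

Compound 4 (`N#Cc1cc2c(nc1N1CCC(C(=O)NS(=O)(=O)C3(c4ccccc4)CC3)CC1)COC2=O`) has not yet been measured. Its change from compound 1 is 1-phenylcyclopropyl in place of 3,5-dichlorobenzyl on a sulfonyl sulfur and puts 1-phenylcyclopropyl in place of 3,5-dichlorobenzyl on a sulfonyl sulfur. For the measured compounds named here, no two measured compounds differ in one place only, so the expectation rests on their values alone. Compound 2 carries a different group on its sulfonyl sulfur, differs elsewhere too, and gives 32800 nM in the same range as compound 1. A small move towards a higher number is therefore expected, within the scatter or only slightly beyond it, and the estimated size is a 1.3-fold higher number from compound 1 to compound 4 (0.12 log units; within the scatter) for this change. In this assay the estimate for compound 4 is 40000 nM with an expected range from 12000 nM to 140000 nM as its bounds.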

Compound 4, half-maximal inhibitory concentration: 4100 nM
Estimate against measurement, compound 4: 9.8-fold (0.99 log units) above; measured number outside the range, below it.
By their numbers in this assay, from the lowest: compound 4; then compounds 1 and 2 (each within the scatter of the next). At a limit, above all of these: compound 3.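

In this assay the exchange of 3,5-dichlorobenzyl for 1-phenylcyclopropyl on a sulfonyl sulfur gives a 7.4-fold lower number from compound 1 to compound 4 (0.87 log units; beyond the scatter) and this is the first step shown in which only one place differs. For the compounds shown here, it establishes that the group at this place moves the read-out, which the earlier compounds, all differing in more than one place, could not show, and that a group with no chlorine can give the lower number. Nothing measured here accounts for the size of this step.

The compounds shown do not separate the loss of the two chlorine atoms from the entry of the three-membered ring. A 1-(3,5-dichlorophenyl)cyclopropyl group or a plain benzyl group on the same sulfonyl sulfur, with the rest of compound 1 unchanged, would bear on that question.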